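The source may hold more compounds than are shown below. What is called first, only, known or untested is meant among the compounds shown, and "the series" means these compounds.

Measured so far in an assay on CHO cells for displacement of a labelled ligand from adenosine receptor A3 (Homo sapiens); on this read-out lower numbers stand for stronger inhibition and higher numbers for weaker inhibition:
compound 1 `CCNC(=O)[C@H]1O[C@@H](n2cnc3c(NC4CC4)nc(Cl)nc32)[C@H](O)[C@@H]1O` — 0.676 nM
compound 2 `O=C(NC1CC1)[C@H]1O[C@@H](n2cnc3c(NC4CC4)nc(Cl)nc32)[C@H](O)[C@@H]1O` — 5.62 nM
compound 3 `CCNC(=O)[C@H]1O[C@@H](n2cnc3c(NCc4cccc(I)c4)nc(Cl)nc32)[C@H](O)[C@@H]1O` — 0.891 nM

Compound 2 differs from compound 1 by one change, (cyclopropyl in place of ethyl on an amide-type nitrogen); in this assay this gave an 8.3-fold higher number from compound 1 to compound 2 (0.92 log units; beyond the scatter). Compound 3 differs from compound 1 in the other arm of the shared core, (3-iodobenzyl in place of cyclopropyl on a nitrogen on an aromatic ring), and in this assay this gave a 1.3-fold higher number from compound 1 to compound 3 (0.12 log units; within the scatter). Among the measured compounds shown here, compound 4 `O=C(NC1CC1)[C@H]1O[C@@H](n2cnc3c(NCc4cccc(I)c4)nc(Cl)nc32)[C@H](O)[C@@H]1O` has not yet been measured; it carries the same change as the one from compound 1 to compound 2, now set on compound 3: cyclopropyl in place of ethyl on an amide-type nitrogen. The two places are the same word for word, so the change is the same. Its step is expected to resemble the earlier one: an estimated 7.9-fold higher number from compound 3 to compound 4 (0.90 log units; beyond the scatter), resting on the step of an 8.3-fold higher number from compound 1 to compound 2 (0.92 log units; beyond the scatter). Compound 4 is therefore estimated at 7 nM in this assay, expected to lie between 2.5 nM and 20 nM.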

Compound 4, inhibition constant: 2.95 nM
The estimate for compound 4 lay 2.4-fold (0.38 log units) above the measured number; low and high end bracket the measured number.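

In this assay, cyclopropyl in place of ethyl on the amide-type nitrogen gives a 3.3-fold higher number from compound 3 to compound 4 (0.52 log units; beyond the scatter), and this step agrees with the one seen on the core of compound 1: the same change on two cores in this assay, an 8.3-fold higher number (0.92 log units; beyond the scatter) from compound 1 to compound 2 and a 3.3-fold higher number (0.52 log units; beyond the scatter) from compound 3 to compound 4, 2.5-fold (0.40 log units) apart, within the scatter of two such steps

The step for 3-iodobenzyl in place of cyclopropyl on a nitrogen on an aromatic ring reads a 1.9-fold lower number from compound 2 to compound 4 (0.28 log units; within the scatter), and it agrees with its counterpart: the same change on two cores in this assay, a 1.3-fold higher number (0.12 log units; within the scatter) from compound 1 to compound 3 and a 1.9-fold lower number (0.28 log units; within the scatter) from compound 2 to compound 4, 2.5-fold (0.40 log units) apart, within the scatter of two such steps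

So each change carried over between these two cores, but each rests on a single pair of steps and shows nothing about other cores or other read-outs.

The compounds shown leave open how a methyl or a propyl on the amide-type nitrogen would read in this assay. They also leave open how a benzyl group without the iodine would read there.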